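Ester variation from compound 1

A few compounds are considered here, and "the series" means these few. Any claim that something is new, unique, unknown or untested is made for them only; others in the source may bear on it.

Compound 1 `CCOC(=O)c1c(-c2cccc(OC)c2)csc1N` gives the higher of the two numbers in an assay on isolated protein for inhibition of protein kinase C zeta type (Homo sapiens), with stated times of 1 h and 2.5 min, tested at 30 uM (on this read-out higher numbers stand for more inhibition at the one concentration tested (going by the name of the read-out) and lower numbers for less inhibition), namely 82%. Among the measured compounds shown here, compound 2 `CCOC(=O)c1c(-c2cccc(C#N)c2)csc1N` gives 32% in this assay, and the only measured step, a number 50 percentage points lower from compound 1 to compound 2 (beyond the scatter), sits on the aromatic ring. Compound 3 `COc1cccc(-c2csc(N)c2C(=O)OCc2ccccc2)c1` differs from compound 1 by phenyl in place of methyl on a saturated chain carbon bound to an oxygen next to a carbonyl group. For the measured compounds named here, this change is at the ester, so no measured step bears on it and the expectation rests on the shared core alone. Relative to compound 1 the step is expected to be small: compound 3 should show a number 10 percentage points lower from compound 1 to compound 3 (within the scatter), not beyond the scatter. The estimated value for compound 3 in this assay is 72%, within 40% to 92%.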

Compound 3, a percentage reported as inhibition, at one concentration (the size of the read-out at that concentration, not a potency): 57%
Compound 3: the middle estimate sits 15 percentage points above what was measured; low and high end bracket the measured number.
By their numbers in this assay, from the lowest: compound 2; then compound 3; then compound 1.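

With the ester as the only difference, phenyl in place of methyl on this saturated chain carbon gives a number 25 percentage points lower from compound 1 to compound 3 (beyond the scatter) in this assay, so this position responds to change. Inhibition falls but does not vanish, as compound 3 still gives 57%. No supporting data offer an explanation for this step.

The compounds shown leave open whether the step follows from the aromatic ring itself or from chain length alone, which a propyl ester could separate. As far as these compounds go, how a carboxylic acid or an amide would read at this place also remains open.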